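Chlorophenyl Pattern Change on the Thioether-Linked Ring

The source may report more compounds than this note shows. Statements on the series, on what has been measured and on what is new or still open speak of the compounds shown alone.

Measured compounds:
compound 1, `COc1cc(-c2nnc(SCc3cccc(Br)c3)o2)ccc1O` — 382000 nM
compound 2, `COc1cc(-c2nnc(SCc3cccc(Cl)c3)o2)ccc1O` — 470000 nM

Compound 2, `COc1cc(-c2nnc(SCc3cccc(Cl)c3)o2)ccc1O`, gives 470000 nM in an ADME assay on cells (Mus musculus, strain BALB/c) for cytotoxicity, read by MTT assay, with a stated time of 24 h; a lower number here means that less compound is tolerated, a higher number that more compound is tolerated. Among the compounds with values here, its only measured neighbour is compound 1, and the two lie within the scatter of each other: a 1.2-fold higher number from compound 1 to compound 2 (0.09 log units; within the scatter), a change of chloro in place of bromo on an aromatic carbon.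

Compound 3, `COc1cc(-c2nnc(SCc3ccccc3Cl)o2)ccc1O`, is not yet measured. It keeps every atom of compound 2 but joins them differently: 2-chlorophenyl in place of 3-chlorophenyl on a saturated chain carbon bound to a sulfur.

Within the data shown here, only one measured step bears on this, a 1.2-fold higher number from compound 1 to compound 2 (0.09 log units; within the scatter), and it exchanges one halogen for another on the same ring rather than exchanging one chlorophenyl for another; it sits within the scatter. Among the measured compounds shown here, no measured step exchanges one chlorophenyl for another. For the measured compounds named here, with no step of that kind to lean on and the one related step being flat, the expectation for compound 3 is a step of no size beyond the scatter, a 1.1-fold lower number from compound 2 to compound 3 (0.04 log units; within the scatter). The estimated value for compound 3 is 430000 nM, expected to fall between 200000 nM and 900000 nM.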

Compound 3, half-maximal cytotoxic concentration: 564000 nM
Estimate against measurement, compound 3: 1.3-fold (0.12 log units) below; the measured number falls inside the stated range.
By their numbers in this assay, from the lowest: compounds 1, 2 and 3 (each within the scatter of the next).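

In this assay, within the data shown here, the first exchange of one chlorophenyl for another gives a 1.2-fold higher number from compound 2 to compound 3 (0.08 log units; within the scatter) and so does not separate 2-chlorophenyl from 3-chlorophenyl on a saturated chain carbon bound to a sulfur. Changing halogen and pattern together gives a 1.5-fold higher number from compound 1 to compound 3 (0.17 log units; within the scatter) and also stays within the scatter, so neither kind of change at this place has yet produced a step beyond it. No measurement is available that would explain these numbers.

The compounds shown leave open whether an amine or a carboxylic acid on this phenyl ring, or a longer chain in place of the saturated chain carbon, would give a step beyond the scatter. As far as these compounds go, the shared core is the same in all three compounds, so its contribution to the read-out also remains open.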